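This account rests on a few compounds, and the source may have more. Where it says the series, first, only, none or still open, it means among the compounds named here.

Measured so far, in a functional assay on HepG2 cells (Homo sapiens) for inhibition, read by MTT assay, with a stated time of 72 h; on this read-out higher numbers stand for weaker inhibition and lower numbers for stronger inhibition:

Compound 1 `CC(C)n1ncc2c(C(=O)Nc3cccnc3)cccc21`. In this assay compound 1 gives > 40000 nM, which is a limit of the assay and not a number.
Compound 2 `Cc1ccc(-n2cc(CNC(=O)c3cccc4c3cnn4C(C)C)nn2)c(C)c1`. In this assay compound 2 gives > 40000 nM, again a limit and not a number.
Compound 3 `CC(C)n1ncc2c(C(=O)NCc3cn(-c4cccc(F)c4)nn3)cccc21`. In this assay compound 3 gives > 40000 nM, likewise a limit and not a number.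

Compound 3 therefore stands where every value shown so far stands: at the limit of > 40000 nM in this assay, at which 3 of the 3 values shown sit. For the measured compounds named here, no compound gives a readable number, so the one measured step, a step that the two limits leave unreadable from compound 2 to compound 3, cannot be sized, and nothing says whether swapping one aromatic group on that nitrogen for another moves inhibition at all.

Compound 4 `COc1ccc(Cn2cc(CNC(=O)c3cccc4c3cnn4C(C)C)nn2)cc1` is the next step. It differs from compound 3 in one place: 4-methoxybenzyl in place of 3-fluorophenyl on an aromatic nitrogen. Going by the values given here, no measured step bears readably on this change, so the expectation for compound 4 rests only on the three values above, all of which sit at the limit. The most likely outcome is that compound 4 also stays at the limit, with no step beyond the scatter in either direction. The expected step is a step that the limit leaves unreadable from compound 3 to compound 4. Compound 4 is estimated at about 60000 nM, with a range from 20000 nM to 200000 nM.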

Compound 4, half-maximal inhibitory concentration: > 40000 nM
Compound 4: no number, only a limit; the forecaster's own chance of this, stated with the estimate: 85%; the middle value does not contradict the limit.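

In this assay compound 4 gives > 40000 nM, which is a limit and not a number. Compound 2 and compound 3 also sit at limits, so the steps from each of them to compound 4 cannot be read. Whether any group on that aromatic nitrogen moves inhibition stays open, because all the values shown stand at one place: the limit of > 40000 nM in this assay, at which 4 of the 4 values shown sit.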